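Replacing the cyano group of compound 3

The compounds below may be only part of what the source reports. "The series", "measured", "known", "first", "only" and "open" are said of these compounds alone.

In a physicochemical assay for solubility, read by nephelometry, measured as kinetic solubility, at pH 2, tested at 10 mg/mL (on this read-out higher numbers stand for higher solubility and lower numbers for lower solubility), compound 3 `Cc1ccccc1C(=O)Nc1ccc(C#N)cn1` gives 6.3 ug/mL, the lowest number among those measured. Compound 2 `Cc1c(C(=O)Nc2ccccn2)ccc(F)c1F` gives 50 ug/mL, a clearly higher number. Compound 1 `COc1ccc(NC(=O)c2ccccc2C)nc1` gives > 100 ug/mL, which is a limit and not a number. Compound 4 `Cc1ccccc1C(=O)Nc1ccc(F)cn1` differs from compound 3 by one change: fluoro in place of cyano on an aromatic carbon. Among the compounds with values here, one measured step bears on this change: an at least 15-fold lower number from compound 1 to compound 3 (1.20 log units; beyond the scatter), a large step that brought in the same cyano group. Going by that step alone, a sizeable move to a higher number is expected in this assay when cyano leaves. The expected step is a 6.3-fold higher number from compound 3 to compound 4 (0.80 log units; beyond the scatter). Compound 4 is estimated at 40 ug/mL, with an expected range of 12 ug/mL to 100 ug/mL.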

Compound 4, solubility: 25 ug/mL
The estimate for compound 4 lay 1.6-fold (0.20 log units) above the measured number; low and high end bracket the measured number.
By their numbers in this assay, from the lowest: compound 3; then compounds 4 and 2 (each within the scatter of the next). At a limit, above all of these: compound 1.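

In this assay, fluoro in place of cyano on this aromatic carbon gives a 4.0-fold higher number from compound 3 to compound 4 (0.60 log units; beyond the scatter), a modest step measured directly at this position. Fluoro in place of methoxy at the same position gives an at least 4.0-fold lower number from compound 1 to compound 4 (0.60 log units; beyond the scatter), so the number for fluoro remains short of the one for methoxy. That step has no upper bound, as compound 1 stands at a limit: the limit of > 100 ug/mL in this assay, at which 1 of the 4 values shown sits.

From the compounds shown here alone, how far methoxy and fluoro truly lie apart stays open. So does how an amine or a carboxylic acid on this carbon would read in this assay.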